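The source may hold more compounds than are shown below. What is called first, only, known or untested is meant among the compounds shown, and "the series" means these compounds.

Series notes. Compound 1 `O=C(NCc1ccc(CNS(=O)(=O)c2ccccc2)cc1)c1ccc(CNc2ncccn2)cc1` gives 1 nM in an assay on MDA-MB-231 cells for binding affinity to C-X-C chemokine receptor type 4 (Homo sapiens), read by microscopy, with stated times of 10 min and 30 min; a lower number here means that less compound is needed, a higher number that more compound is needed for the effect. Compound 2 `O=C(NCc1ccc(CNS(=O)(=O)c2cccc(F)c2)cc1)c1ccc(CNc2ncccn2)cc1` gives 1000 nM, and compound 3 `Cc1ccccc1S(=O)(=O)NCc1ccc(CNC(=O)c2ccc(CNc3ncccn3)cc2)cc1` gives 10 nM. The steps are all beyond the scatter: a 1000-fold higher number from compound 1 to compound 2 (3.00 log units; beyond the scatter), a 10-fold higher number from compound 1 to compound 3 (1.00 log units; beyond the scatter), and a 100-fold lower number from compound 2 to compound 3 (2.00 log units; beyond the scatter). Compound 3 therefore stands second highest of the three numbers, nearer to compound 1 than to compound 2.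

Compound 4 `Cc1ccc(S(=O)(=O)NCc2ccc(CNC(=O)c3ccc(CNc4ncccn4)cc3)cc2)cc1` is the next step, not yet measured: 4-methylphenyl in place of 2-methylphenyl on a sulfonyl sulfur. The change keeps every atom of compound 3 and only relocates the methyl on the ring that sits on the sulfonyl sulfur. Going by the values given here, the steps that bear on it are those that alter this same ring: the small addition in the step from compound 1 to compound 3 cost a modest amount, while the fluoro in the step from compound 1 to compound 2 cost a large amount. Both show that the assay is sensitive to what this ring carries and where, but neither tests a 4-methylphenyl, so no direct anchor exists for compound 4.

The expectation for compound 4 is a step of about a 3.0-fold higher number from compound 3 to compound 4 (0.48 log units; beyond the scatter) in the assay, with a wide range because the ring changes in compound 2 and compound 3 span a 100-fold lower number from compound 2 to compound 3 (2.00 log units; beyond the scatter). Compound 4 is estimated at 30 nM, within 1 nM to 1000 nM.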

Compound 4, effective concentration (reported as EC, without a stated level of effect): 100 nM
Estimate against measurement, compound 4: 3.3-fold (0.52 log units) below; low and high end bracket the measured number.
By their numbers in this assay, from the lowest: compound 1; then compound 3; then compound 4; then compound 2.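

Moving the methyl, with the atoms unchanged, is enough to shift the number in this assay by a 10-fold higher number from compound 3 to compound 4 (1.00 log units; beyond the scatter) on the ring on the sulfonyl sulfur, so in this pair the reading depends on where the methyl sits and not only on its presence. Set against the unsubstituted ring, 4-methylphenyl gives a 100-fold higher number from compound 1 to compound 4 (2.00 log units; beyond the scatter) and so costs more than the 2-methylphenyl of compound 3, while a 10-fold lower number from compound 2 to compound 4 (1.00 log units; beyond the scatter) places it short of the 3-fluorophenyl of compound 2; each of the three substituted rings therefore reads higher than the plain phenyl of compound 1, and the order among them follows neither the group nor its place alone. Nothing available gives a reason for this dependence on position.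

As far as these compounds go, compound 2 differs from compound 3 and compound 4 in both the group and its place, so a 3-methylphenyl and a 4-fluorophenyl remain open as the rings that would separate those two changes. Also open, from the compounds shown here alone, is how this ring would read with a larger or charged group on it, such as a methoxy, an amine or a carboxylic acid.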